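Amine swap on a shared core: piperidine replaces methoxybenzyl-methylamine

The compounds below may be only part of what the source reports. "The series", "measured", "known", "first", "only" and "open" are said of these compounds alone.

Measured compounds:
compound 1, `COc1ccccc1CN(C)Cc1ccc(/C=C2\Oc3cc(OC)c(OC)cc3C2=O)cc1O`, 8.4%
compound 2, `COc1cc2c(cc1OC)C(=O)/C(=C/c1ccc(CN(C)Cc3ccccc3)c(O)c1)O2`, 17.8%
compound 3, `COc1cc2c(cc1OC)C(=O)/C(=C/c1ccc(CN3CCN(Cc4ccccc4)CC3)c(O)c1)O2`, 6.9%

All three were tested in an assay on cells for inhibition of Amine oxidase [flavin-containing] B (Homo sapiens), read by fluorescence, with a stated time of 30 min, tested at 10 uM; on this read-out lower numbers stand for less inhibition and higher numbers for more inhibition at the one concentration tested (going by the name of the read-out). Compound 1 stands second highest of the three numbers; its nearest neighbour is compound 3, and its furthest is compound 2, both within the scatter. Among the measured compounds shown here, the one step measured between single-point differences, a number 9.4 percentage points higher from compound 1 to compound 2 (within the scatter), is within the scatter. Compound 4, `COc1cc2c(cc1OC)C(=O)/C(=C/c1ccc(CN3CCCCC3)c(O)c1)O2`, differs from compound 1 by piperidin-1-yl in place of (2-methoxybenzyl)(methyl)amino on a saturated chain carbon bound to an aromatic carbon. For the measured compounds named here, only the step from compound 1 to compound 2 bears on this change, and it was small; compound 3, which carries a different amine, shows a number close to compound 1. Compound 4 is therefore expected to give 10% (range 2% to 22%), a step of a number 1.6 percentage points higher from compound 1 to compound 4 (within the scatter), expected to lie within the scatter.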

Compound 4, a percentage reported as inhibition, at one concentration (the size of the read-out at that concentration, not a potency): 32%
Beside the measured number, compound 4's estimate is 22 percentage points below it; measured number above the stated range.
By their numbers in this assay, from the lowest: compounds 3, 1 and 2 (each within the scatter of the next, the first and the last beyond it); then compound 4.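

In this assay, piperidin-1-yl in place of (2-methoxybenzyl)(methyl)amino gives a number 23.6 percentage points higher from compound 1 to compound 4 (beyond the scatter) and in place of benzyl(methyl)amino gives a number 14.2 percentage points higher from compound 2 to compound 4 (beyond the scatter). Both steps lie beyond the scatter, so the amine on this saturated chain carbon does shift the read-out, which the step between compound 1 and compound 2 had not shown. No evidence is at hand to account for this shift.

On these data alone, whether a pyrrolidine, a morpholine or a dimethylamino group at this place would read higher or lower stays open. As far as these compounds go, the potency of compound 4 also stays open, since this read-out gives one concentration only.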